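A few compounds are considered here, and "the series" means these few. Any claim that something is new, unique, unknown or untested is made for them only; others in the source may bear on it.

In a functional assay on MCF7 cells (Homo sapiens) for cytotoxicity, read by sulforhodamine B assay, with a stated time of 48 h (on this read-out lower numbers stand for stronger inhibition and higher numbers for weaker inhibition), compound 1 (`C=CCOc1ccc(F)cc1C(=O)c1cccnc1`) gives > 100000 nM, which is a limit of the assay. Compound 2 (`C=CCOc1c(Cl)cccc1C(=O)c1cccnc1`) gives > 100000 nM, also a limit. Within the data shown here, compound 3 (`C=CCOc1ccc(C)cc1C(=O)c1cccnc1`) gives 84000 nM, the only value that is a number, and it stands close to the limit of > 100000 nM in this assay, at which 2 of the 3 values shown sit.

Compound 4 (`C=CCOc1ccccc1C(=O)c1cccnc1`) has hydrogen in place of methyl on an aromatic carbon, para to an allyloxy group: hydrogen in place of methyl on an aromatic carbon.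

Among the measured compounds shown here, one measured step touches this carbon, methyl in place of fluoro: an at least 1.1-fold lower number from compound 1 to compound 3 (0.07 log units; that floor lies within the scatter). With so small a measured step, no change beyond the scatter is expected in this assay, and a reading at the limit is plausible. The expected change is a 1.1-fold higher number from compound 3 to compound 4 (0.05 log units; within the scatter). For compound 4 the estimated value is 95000 nM, with an expected range of 50000 nM to 180000 nM.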

Compound 4, half-maximal inhibitory concentration: > 100000 nM
Compound 4 ended at the assay's limit; the forecaster's own chance of this, stated with the estimate: 55%; middle value at least 1.0-fold (0.02 log units) from the limit.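

Hydrogen in place of methyl on this aromatic carbon, para to an allyloxy group, gives an at least 1.1-fold higher number from compound 3 to compound 4 (0.07 log units; that floor lies within the scatter) in this assay; the true size of the step stays unknown, so the methyl is neither shown to matter nor ruled out. The steps from compound 1 and from compound 2 to compound 4 have limits at both ends and cannot be read. The unsubstituted compound 4 joins the ceiling of the series: the limit of > 100000 nM in this assay, at which 3 of the 4 values shown sit.

Open, going by these compounds, is whether an amine or a carboxylic acid on this carbon would give a number clearly below that limit. Also open, on these data alone, is whether a longer chain in place of the allyloxy group would do so.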